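Adding a 4-methoxyphenyl where three sulfonamides showed nothing

This account rests on a few compounds, and the source may have more. Where it says the series, first, only, none or still open, it means among the compounds named here.

Measured so far in an assay on isolated protein for inhibition of malate dehydrogenase, mitochondrial (Sus scrofa), with stated times of 45 min and 30 min; a lower number here means a stronger inhibitor, a higher number a weaker inhibitor:
- compound 1, `O=S(=O)(Nc1ccc2oc(-c3ccccc3)nc2c1)c1ccccc1O`: compound 1 gives > 63000 nM, a limit.
- compound 2, `O=S(=O)(Nc1ccc2oc(-c3ccccc3)nc2c1)c1ccc(O)cc1`: compound 2 gives > 63000 nM, a limit.
- compound 3, `CS(=O)(=O)Nc1ccc2oc(-c3ccccc3)nc2c1`: compound 3 gives > 63000 nM, a limit.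

Compound 3 therefore stands at the same limit as the others, with no number of its own; this is the limit of > 63000 nM in this assay, at which 3 of the 3 values shown sit. The steps between them, a step that the two limits leave unreadable from compound 1 to compound 2, a step that the two limits leave unreadable from compound 1 to compound 3 and a step that the two limits leave unreadable from compound 2 to compound 3, are unreadable, so no size can be taken from them.

Compound 4, `COc1ccc(S(=O)(=O)Nc2ccc3oc(-c4ccccc4)nc3c2)cc1`, changes the sulfonyl group again: 4-methoxyphenyl in place of methyl on a sulfonyl sulfur. Because the limit of > 63000 nM in this assay, at which 3 of the 3 values shown sit, holds for every measured relative, no step is expected beyond the scatter; the estimated step is a step that the limit leaves unreadable from compound 3 to compound 4. Compound 4 is thus expected at 100000 nM, in the range 40000 nM to 300000 nM.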

Compound 4, half-maximal inhibitory concentration: > 63000 nM
Compound 4: a limit, no number; the forecaster's own chance of this, stated with the estimate: 85%; the middle value lies beyond the limit too.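

Compound 4 gives only a limit, as do compound 1, compound 2 and compound 3, so no step among them can be read: the limit of > 63000 nM in this assay, at which 4 of the 4 values shown sit.

The compounds shown leave open how strongly each one actually inhibits in this assay.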